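The source may report more compounds than this note shows. Statements on the series, on what has been measured and on what is new or still open speak of the compounds shown alone.

Measured compounds in a functional assay on A549 cells (Homo sapiens) for cytotoxicity, read by MTT assay, with a stated time of 24 h, tested at 20 uM; a lower number here means a stronger effect, a higher number a weaker effect of the compound at the concentration tested:
- compound 1, `CCCCOC(=O)CCC(=O)N1CCN(CCCOc2cc3c(Nc4ccc(F)c(Cl)c4)ncnc3cc2OC)CC1`: compound 1 gives 86%
- compound 2, `CCCCCOC(=O)CCC(=O)N1CCN(CCCOc2cc3c(Nc4ccc(F)c(Cl)c4)ncnc3cc2OC)CC1`: compound 2 gives 81.2%
- compound 3, `CCCCCCCCOC(=O)CCC(=O)N1CCN(CCCOc2cc3c(Nc4ccc(F)c(Cl)c4)ncnc3cc2OC)CC1`: compound 3 gives 80%

The three share one core and differ only in the ester chain. From compound 1 to compound 2 the change is methyl in place of hydrogen on a saturated chain carbon, four bonds along the chain from an oxygen next to a carbonyl group and it gave a number 4.8 percentage points lower from compound 1 to compound 2 (within the scatter). Compound 3 carries the longer chain, (butyl in place of hydrogen on a saturated chain carbon, four bonds along the chain from an oxygen next to a carbonyl group), and its steps of a number 6 percentage points lower from compound 1 to compound 3 (within the scatter) and a number 1.2 percentage points lower from compound 2 to compound 3 (within the scatter) likewise stay within the scatter.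

Compound 4, `CCCCCCCCCOC(=O)CCC(=O)N1CCN(CCCOc2cc3c(Nc4ccc(F)c(Cl)c4)ncnc3cc2OC)CC1`, is not yet measured. It differs from compound 3 by methyl in place of hydrogen on a saturated chain carbon, eight bonds along the chain from an oxygen next to a carbonyl group. This is the same kind of change as from compound 1 to compound 2, though not the same: there the place was four bonds along the chain from an oxygen next to a carbonyl group, here it is eight bonds along the chain from an oxygen next to a carbonyl group. Because a number 4.8 percentage points lower from compound 1 to compound 2 (within the scatter) and a number 1.2 percentage points lower from compound 2 to compound 3 (within the scatter) both lie within the scatter, the expected step is a number 1 percentage points lower from compound 3 to compound 4 (within the scatter), beside the earlier one. Compound 4 is estimated at 79%, expected between 68% and 90%.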

Compound 4, a percentage reported as activity, at one concentration (the size of the read-out at that concentration, not a potency): 79.7%
The estimate for compound 4 lay 0.7 percentage points below the measured number, within the range that was stated.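

In this assay, methyl on the longer chain gave a number 0.3 percentage points lower from compound 3 to compound 4 (within the scatter), and this step reads the same as its earlier counterpart: the same change on two cores in this assay, a number 4.8 percentage points lower (within the scatter) from compound 1 to compound 2 and a number 0.3 percentage points lower (within the scatter) from compound 3 to compound 4, 4.5 percentage points apart, within the scatter of two such steps. Butyl in place of hydrogen gave a number 1.5 percentage points lower from compound 2 to compound 4 (within the scatter), matching the earlier butyl step, while pentyl in place of hydrogen gave a number 6.3 percentage points lower from compound 1 to compound 4 (within the scatter), which has no counterpart to set it beside: the same change on two cores in this assay, a number 6 percentage points lower (within the scatter) from compound 1 to compound 3 and a number 1.5 percentage points lower (within the scatter) from compound 2 to compound 4, 4.5 percentage points apart, within the scatter of two such steps. Within these four compounds the steps therefore carry from one ester chain to another without a detectable difference, but as every step lies within the scatter, this shows only the absence of a measurable step and not that a step of real size would carry over in the same way.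

As far as these compounds go, whether an amine, a carboxylic acid or a chain longer than that of compound 4 in place of this ester chain would give a step beyond the scatter in this assay stays open. From the compounds shown here alone, the shared core is the same in all four compounds, so the effect of any change to it also stays open.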